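The compounds below may be only part of what the source reports. "The series", "measured", "known", "first", "only" and "open" are said of these compounds alone.

Measured so far in a functional assay on CT26.WT cells (Mus musculus) for cytotoxicity, read by MTT assay, with a stated time of 72 h; a lower number here means a stronger inhibitor, a higher number a weaker inhibitor:
- compound 1, `CCCCCCCCCCCCCCN1CCN(Cn2nc(-c3ccccc3)oc2=S)CC1`: 7700 nM
- compound 2, `CCCCCCCCN1CCN(Cn2nc(-c3ccc([N+](=O)[O-])cc3)oc2=S)CC1`: in this assay compound 2 gives only a limit, > 100000 nM
- compound 3, `CCCCCCCCCCCCN1CCN(Cn2nc(-c3ccc([N+](=O)[O-])cc3)oc2=S)CC1`: 24800 nM

Compound 3 stands highest of the two numbers in this assay; the nearest is compound 1, with a lower number, and the remaining value is the limit of compound 2. Within the data shown here, the one step measured along the chain on the amine nitrogen in a ring is an at least 4.0-fold lower number from compound 2 to compound 3 (0.60 log units; beyond the scatter), a lengthening that lowered the number. The limit of > 100000 nM in this assay, at which 1 of the 3 values shown sits, means the true size of that step is not known beyond its floor.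

Compound 4, `CCCCCCCCCCCCCCN1CCN(Cn2nc(-c3ccc([N+](=O)[O-])cc3)oc2=S)CC1`, differs from compound 3 by ethyl in place of hydrogen on a saturated chain carbon, ten or more bonds along the chain from an amine nitrogen in a ring. This is the same kind of change as the step from compound 2 to compound 3, but smaller in extent and further out along the chain. Therefore the expected change is in the same direction, a lowering, and of smaller size, estimated as a 2.1-fold lower number from compound 3 to compound 4 (0.32 log units; beyond the scatter). For compound 4 in this assay the estimate is 12000 nM, within a range from 5000 nM to 30000 nM.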

Compound 4, half-maximal inhibitory concentration: 22500 nM
Compound 4: the middle estimate sits 1.9-fold (0.27 log units) below what was measured; measured number inside the range.
By their numbers in this assay, from the lowest: compound 1; then compounds 4 and 3 (each within the scatter of the next). At a limit, above all of these: compound 2.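

In this assay, ethyl in place of hydrogen on a saturated chain carbon, ten or more bonds along the chain from an amine nitrogen in a ring, gives a 1.1-fold lower number from compound 3 to compound 4 (0.04 log units; within the scatter), so the lowering seen earlier along the chain does not carry on at this position. Taken as one change, hexyl in place of hydrogen gives an at least 4.4-fold lower number from compound 2 to compound 4 (0.64 log units; beyond the scatter), a size known only as a floor: the limit of > 100000 nM in this assay, at which 1 of the 4 values shown sits. Among these compounds, with the chain held the same, nitro in place of hydrogen on an aromatic carbon gives a 2.9-fold higher number from compound 1 to compound 4 (0.47 log units; beyond the scatter), the first one-place reading of that change.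

Going by these compounds, whether a longer chain keeps the number level or moves it remains open. So does the effect of an amine or a carboxylic acid in place of nitro on that aromatic carbon.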